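Phenyl carbamate in place of the ester side chain

The source may hold more compounds than are shown below. What is called first, only, known or untested is meant among the compounds shown, and "the series" means these compounds.

Two compounds on the shared core carry a measurement. Compound 1 `COC(=O)COc1cccc(-n2cnc(-c3ccccc3)c2-c2ccccc2)c1` is the weaker of the two to give a number: in an assay on H4 cells for inhibition of Fatty-acid amide hydrolase 1 (Homo sapiens) (a lower number here means a stronger inhibitor, a higher number a weaker inhibitor), compound 1 gives 6500 nM. Compound 2 `CCOC(=O)CC(CCCCCn1c(C)nc(-c2ccccc2)c1-c1ccccc1)C(C)C` is recorded only as a limit of this assay, where compound 2 gives > 100000 nM. That limit marks the upper edge of what this assay reports, and compound 2 sits at it, as noted in the limit of > 100000 nM in this assay, at which 1 of the 2 values shown sits; its true value is not known beyond that.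

Compound 3 `Cc1nc(-c2ccccc2)c(-c2ccccc2)n1CCCCCCNC(=O)Oc1ccccc1` is not yet measured. It differs from compound 2 in one place: ((phenoxycarbonyl)amino)methyl in place of 1-((ethoxycarbonyl)methyl)-2-methylpropyl on a saturated chain carbon, five bonds along the chain from an aromatic nitrogen. Going by the values given here, no measured pair shows this change, so the size of the step can only be guessed from the two values given. Compound 2 stands at a limit, which leaves room for a large step downward, and a large step toward stronger inhibition is what is expected here, an at least 250-fold lower number from compound 2 to compound 3 (2.39 log units; beyond the scatter). For compound 3 the expected value in this assay is 400 nM, with a range from 40 nM to 4000 nM.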

Compound 3, half-maximal inhibitory concentration: 5.3 nM
For compound 3 the middle estimate is 75-fold (1.88 log units) above the measured one, and the stated range ends above it.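

In this assay, ((phenoxycarbonyl)amino)methyl in place of 1-((ethoxycarbonyl)methyl)-2-methylpropyl on a saturated chain carbon, five bonds along the chain from an aromatic nitrogen, gives an at least 18000-fold lower number from compound 2 to compound 3 (4.27 log units; beyond the scatter). Going by these compounds alone, this is the first single-place change, and it shows that the group at the end of this chain can by itself decide between no readable inhibition and a low-nanomolar number, with compound 3 at 5.3 nM; compounds 1 and 2 differ in more than one place and could not show this. The true size of the step remains unknown, and only its lower bound can be read, because compound 2 stands at a limit of the assay: the limit of > 100000 nM in this assay, at which 1 of the 3 values shown sits.

The single change swaps the whole group, so the compounds shown do not separate the contributions of the carbamate carbonyl, the amide hydrogen and the phenyl ring. On these data alone, how a urea in place of the carbamate, a cyclohexyl in place of the phenyl, or a shorter or longer chain would read in this assay stays open.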